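The compounds below may be only part of what the source reports. "The series", "measured", "known", "first", "only" and "open" are said of these compounds alone.

Three members of the series have been run in a functional assay on cells for agonist activity at C-X-C chemokine receptor type 4 (Homo sapiens), read by fluorescence and calcium flux, with a stated time of 90 s; on this read-out lower numbers stand for an effect already at smaller amounts and higher numbers for an effect only at larger amounts of compound. Compound 1 `c1ccc(CNCCCCN(C[C@H]2Cc3ccccc3CN2)[C@H]2CCCc3cccnc32)cc1` returns only a limit in this assay, > 30000 nM. Compound 2 `c1ccc2c(c1)CN[C@@H](CN(CCCCNCC1CCCCC1)[C@H]1CCCc3cccnc31)C2` likewise gives a limit in this assay, > 30000 nM. Compound 3 `c1ccc2c(c1)CN[C@@H](CN(CCCCNCC1CCSCC1)[C@H]1CCCc3cccnc31)C2` also sits at a limit in this assay, > 30000 nM. The steps a step that the two limits leave unreadable from compound 1 to compound 2, a step that the two limits leave unreadable from compound 1 to compound 3 and a step that the two limits leave unreadable from compound 2 to compound 3 therefore cannot be sized from these numbers. Compound 3 thus stands where every measured member stands, namely at the limit of > 30000 nM in this assay, at which 3 of the 3 values shown sit.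

Compound 4 `c1ccc2c(c1)CN[C@@H](CN(CCCCNC1CCCCC1)[C@H]1CCCc3cccnc31)C2` differs from compound 3 by cyclohexyl in place of (thian-4-yl)methyl on an amine nitrogen. Among the measured compounds shown here, none of the measured steps bears on a change of this kind with a readable size; the only guide is that all three measured compounds stay at the limit, whatever group sits on that amine nitrogen. The expectation is that compound 4 again shows no readable effect in this assay, an estimated step that the limit leaves unreadable from compound 3 to compound 4. The estimated value for compound 4 is 40000 nM, with an expected range from 6000 nM to 150000 nM, and the assay is expected most likely to report only a limit once more.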

Compound 4, half-maximal effective concentration: > 30000 nM
Compound 4 ended at the assay's limit; the forecaster's own chance of this, stated with the estimate: 80%; the middle value is on the limit's open side.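

In this assay compound 4 gives > 30000 nM, which is a limit and not a number. Among the compounds shown here, no new step to compound 4 from compound 1, compound 2 or compound 3 can be read, and all four compounds stand together: the limit of > 30000 nM in this assay, at which 4 of the 4 values shown sit. The compounds shown leave open whether any group on that amine nitrogen gives a readable effect in this assay.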